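Notes on ring-substituent moves in the shared core series

The source may hold more compounds than are shown below. What is called first, only, known or untested is meant among the compounds shown, and "the series" means these compounds.

Compound 1 `O=C1CSC(c2ccccc2Cl)N1CCN1CCCCC1` is one of three analogues measured in an ADME assay on Vero cells (Chlorocebus sabaeus) for cytotoxicity, read by neutral red uptake, tested at 12.3 ug/mL; a lower number here means a stronger effect, a higher number a weaker effect of the compound at the concentration tested. In this assay compound 1 gives 100%, compound 2 `O=C1CSC(c2c(Cl)cccc2Cl)N1CCN1CCCCC1` gives 100%, and compound 3 `O=C1CSC(c2ccccc2[N+](=O)[O-])N1CCN1CCCCC1` gives 100%; all three stand level within the scatter. The step of no change at the digits printed from compound 1 to compound 2 (within the scatter) and the step of no change at the digits printed from compound 1 to compound 3 (within the scatter) were both flat. Compound 4 `O=C1CSC(c2cccc(Cl)c2)N1CCN1CCCCC1` differs from compound 1 by 3-chlorophenyl in place of 2-chlorophenyl on a saturated ring carbon. For the measured compounds named here, no measured step covers a move of the chloro on the aryl group; the flat steps seen so far, however, give no hint of any movement. The expected step of no change at the digits printed from compound 1 to compound 4 (within the scatter) is therefore nothing beyond the scatter. Compound 4 is estimated at 100%, in the range 88% to 105%.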

Compound 4, a percentage reported as activity, at one concentration (the size of the read-out at that concentration, not a potency): 100%
Beside the measured number, compound 4's estimate shows no gap at the digits printed; low and high end bracket the measured number.
By their numbers in this assay, from the lowest: compounds 1, 2, 3 and 4 (each within the scatter of the next).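

In this assay the move of the chloro on the aryl group gives no change at the digits printed from compound 1 to compound 4 (within the scatter), so 3-chlorophenyl and 2-chlorophenyl on this saturated ring carbon read alike. The earlier steps shown here changed which groups the aryl group carries; this one changes only where the chloro sits, and that too leaves the read-out flat. Nothing at hand gives a reason for this flat result.

Going by these compounds, whether a carboxylic acid or an amine on the aryl group would shift the read-out remains open. So does the effect of a longer chain in place of the ethylene link on the shared core.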